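Oxazole carboxamides and a bicyclic ester: cytotoxicity notes

The source may report more compounds than this note shows. Statements on the series, on what has been measured and on what is new or still open speak of the compounds shown alone.

Measured so far:
compound 1 `O=C(NCc1ccccc1)c1coc(-c2ccccc2)n1` — "not determined" (no result reported)
compound 2 `Cc1cc2nc(C)c(C(=O)OCc3ccccc3)n2c(C)n1` — > 50000 nM

In an ADME assay on Vero cells (Chlorocebus sabaeus) for cytotoxicity, with a stated time of 72 h (a higher number here means a weaker inhibitor, a lower number a stronger inhibitor), compound 1 has no single number; its entry reads "not determined" (no result reported). For compound 2 the assay gives only a limit, > 50000 nM, so no number stands behind it either. Among the compounds with values here, the one further value shown is therefore the limit of > 50000 nM in this assay, at which 1 of the 2 values shown sits, and nothing else; compound 1 stands beside an empty entry and a limit, with no measured step between any two compounds.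

Compound 3 `O=C(Nc1ccccc1)c1coc(-c2ccccc2)n1` is the next compound to be run. It differs from compound 1 by phenyl in place of benzyl on an amide-type nitrogen. Within the data shown here, no step in this assay is known for any pair, so the expectation for this change rests on structure alone: a step of no size beyond the usual scatter, in either direction, is expected in this assay.

The estimate for compound 3 in this assay is 40000 nM, with an expected range from 10000 nM to 100000 nM, and a fair chance that, as for compound 2, only a limit is reported.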

Compound 3, half-maximal inhibitory concentration: > 128000 nM
Compound 3 was reported as a limit; the forecaster's own chance of this, stated with the estimate: 65%; at least 3.2-fold (0.50 log units) between middle value and limit.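

Within the data shown here, compound 3 gives only a limit in this assay, > 128000 nM, and compound 1 has no number there; no step between compound 1 and compound 3 can be read. The compounds shown leave open whether phenyl in place of benzyl on an amide-type nitrogen changes the half-maximal inhibitory concentration in this assay at all.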